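Trifluoromethoxy on the chloro compound

This account rests on a few compounds, and the source may have more. Where it says the series, first, only, none or still open, it means among the compounds named here.

In a functional assay on Jurkat cells (Homo sapiens) for antiproliferative activity, read by MTT assay, with a stated time of 72 h (on this read-out higher numbers stand for weaker inhibition and lower numbers for stronger inhibition), compound 1 `COc1ccc(-c2ncnn2-c2cc(OC)c(OC)c(OC)c2)cc1` gives 50 nM. Compound 2 `COc1cc(-n2ncnc2-c2ccc(Cl)cc2)cc(OC)c1OC` reads > 10000 nM, which is a limit of the assay and not a number. Compound 2 therefore stands at the limit of > 10000 nM in this assay, at which 1 of the 2 values shown sits, with no measured position of its own. Among the measured compounds shown here, the only measured step is an at least 200-fold higher number from compound 1 to compound 2 (2.30 log units; beyond the scatter), large and beyond the scatter, with chloro in place of methoxy on an aromatic carbon.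

Compound 3 `COc1cc(-n2ncnc2-c2ccc(OC(F)(F)F)cc2)cc(OC)c1OC` carries the change trifluoromethoxy in place of chloro on an aromatic carbon, para to a large group. For the measured compounds named here, no measured compound holds trifluoromethoxy, so the one step bears on this change only indirectly. Going by that step, only a partial return towards compound 1 at 50 nM is expected in this assay, with the direction towards lower numbers. There is a real chance that compound 3 meets the limit again. The expected step is an at least 2.5-fold lower number from compound 2 to compound 3 (0.39 log units; beyond the scatter). For compound 3 the estimate is 4000 nM, with an expected range of 500 nM to 10000 nM.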

Compound 3, half-maximal inhibitory concentration: > 10000 nM
Compound 3: only a limit was reported (the forecaster's own chance of this, stated with the estimate: 45%); at least 2.5-fold (0.39 log units) between middle value and limit.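

Trifluoromethyl in place of methyl on the oxygen on the aromatic ring gives an at least 200-fold higher number from compound 1 to compound 3 (2.30 log units; beyond the scatter) in this assay, so this single change to the methoxy group is enough for a large loss. Among the compounds shown here, the loss is therefore not specific to chloro: the two different groups tried in place of the methoxy, on the same aromatic carbon para to a large group, both leave the measured range, and methoxy remains the only group here with a measured number. The step between the two chloro and trifluoromethoxy compounds cannot be read, so these two groups cannot be ranked, and most of the series now sits at a limit rather than at a number: the limit of > 10000 nM in this assay, at which 2 of the 3 values shown sit.

Going by these compounds, it remains open whether any group other than methoxy at this carbon can return a measured value, for example an amine such as dimethylamino, a hydroxyl, or fluoro. Also open, on these data alone, is whether ethoxy, a longer chain on the same oxygen, would hold up as methoxy does or fall to the limit as well.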